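The source may report more compounds than this note shows. Statements on the series, on what has been measured and on what is new or still open speak of the compounds shown alone.

In a functional assay on DU-145 cells (Homo sapiens) for cytotoxicity, read by ELISA, with a stated time of 2 days (on this read-out higher numbers stand for weaker inhibition and lower numbers for stronger inhibition), compound 1 (`Oc1ccc(-c2cc(-c3ccccc3)cc(-c3cccs3)n2)cc1`) gives 3700 nM and compound 2 (`Oc1ccc(-c2cc(-c3ccccc3)cc(-c3ccco3)n2)cc1`) gives 3200 nM. Compound 2 therefore stands level with compound 1 within the scatter, and no other measured number is available for comparison. Compound 3 (`Oc1ccc(-c2cc(-c3ccccc3)cc(-c3ccc(O)cc3)n2)cc1`) retains the shared core of compound 2 but carries 4-hydroxyphenyl in place of furan-2-yl on an aromatic carbon, next to the ring nitrogen: 4-hydroxyphenyl in place of furan-2-yl on an aromatic carbon. Within the data shown here, only one measured step bears on this place, a 1.2-fold lower number from compound 1 to compound 2 (0.06 log units; within the scatter), where furan-2-yl replaces thiophen-2-yl. Among the measured compounds shown here, that small step offers limited guidance, since no measured compound has a six-membered aromatic ring of carbon only at this place. The data therefore give no basis for predicting a direction, and no shift beyond the scatter is expected, although the range must stay wide. The expected change is a 1.1-fold lower number from compound 2 to compound 3 (0.03 log units; within the scatter). In this assay, the estimate for compound 3 is 3000 nM, with an expected range from 800 nM to 12000 nM.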

Compound 3, half-maximal inhibitory concentration: 22000 nM
Beside the measured number, compound 3's estimate is 7.3-fold (0.87 log units) below it, and the stated range ends below it.
By their numbers in this assay, from the lowest: compounds 2 and 1 (each within the scatter of the next); then compound 3.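

In this assay, the two five-membered aromatic rings had not told this place apart, but 4-hydroxyphenyl does separate from them, with both steps beyond the scatter and toward weaker inhibition (a 6.9-fold higher number from compound 2 to compound 3 (0.84 log units; beyond the scatter); a 5.9-fold higher number from compound 1 to compound 3 (0.77 log units; beyond the scatter)). The place next to the ring nitrogen therefore responds to what it carries, and a six-membered aromatic ring of carbon only bearing a hydroxyl is not tolerated here as well as furan-2-yl or thiophen-2-yl. Nothing measured on these compounds accounts for the loss.

The change alters several things at once, replacing a five-membered ring with a six-membered one and adding a hydrogen-bond donor, so the compounds shown cannot say whether the higher number goes with the larger ring or with its hydroxyl. From the compounds shown here alone, how an unsubstituted phenyl, a 4-methoxyphenyl or a 4-aminophenyl would read at this place stays open, and so does whether a small amine or a short alkyl chain here would hold the level of the two five-membered rings.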